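Swapping a Pyrazole for a Triazole on a Hydrazide

The source may report more compounds than this note shows. Statements on the series, on what has been measured and on what is new or still open speak of the compounds shown alone.

Of the compounds shown here, three have so far been measured in an ADME assay on microsomes from liver (Mus musculus) for metabolic stability, read by HPLC, using NADPH, with a stated time of 60 min, tested at 1 uM, in the presence of a further agent that is not named here; on this read-out lower numbers stand for slow clearance and higher numbers for fast clearance. Compound 1 `O=C(NNS(=O)(=O)c1ccccc1F)c1cc(F)cc(-n2cccn2)c1` gives 334 uL/min. Compound 2 `Cc1cc(-n2cccn2)cc(C(=O)NNS(=O)(=O)c2ccccc2)c1F` gives 567 uL/min in this assay; compound 1 and compound 2 sit within the usual scatter of each other, so the two cannot be ranked. Compound 3 `Cc1cc(OC(C)C)cc(C(=O)NNS(=O)(=O)c2ccccc2F)c1` gives no number in this assay but only a limit, > 866 uL/min, which is the limit of > 866 uL/min in this assay, at which 1 of the 3 values shown sits.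

Compound 4 `Cc1cc(-n2nccn2)cc(C(=O)NNS(=O)(=O)c2ccccc2)c1F` is still unmeasured. It differs from compound 2 in one place: 2H-1,2,3-triazol-2-yl in place of 1H-pyrazol-1-yl on an aromatic carbon. Among the measured compounds shown here, no pair of measured compounds shows this kind of change, so there is no measured step to lean on. With both rings of similar size, the expected step of a 1.4-fold lower number from compound 2 to compound 4 (0.13 log units; within the scatter) is judged small, within or near the scatter, and leaning toward lower clearance only slightly. Compound 4 is therefore estimated to give 420 uL/min in this assay, with a range from 180 uL/min to 866 uL/min.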

Compound 4, intrinsic clearance in a liver preparation (reported as CLH), per the amount of preparation that the assay uses in the Mus musculus assay: 865 uL/min
Compound 4: middle estimate off by 2.1-fold (0.31 log units), on the low side; measured number inside the range.
By their numbers in the Mus musculus assay, from the lowest: compounds 1, 2 and 4 (each within the scatter of the next, the first and the last beyond it). At a limit, above all of these: compound 3.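

In the Mus musculus assay, putting 2H-1,2,3-triazol-2-yl in place of 1H-pyrazol-1-yl on this aromatic carbon gives a 1.5-fold higher number from compound 2 to compound 4 (0.18 log units; within the scatter), so no change in clearance can be read from this swap. In a physicochemical assay for solubility, read by nephelometry, in phosphate buffer, measured as kinetic solubility, at pH 6.5 (a higher number here means a more soluble compound, a lower number a less soluble compound), compound 2 gives 6.3 ug/mL and compound 4 gives 25 ug/mL. This one-place change therefore raises solubility without a readable shift in clearance: the measured solubility of compound 2, 6.3 ug/mL, and of compound 4, 25 ug/mL, a 4.0-fold higher number (0.60 log units; beyond the scatter)

The compounds shown leave open whether the same swap would act the same way on the core of compound 1. They also leave open whether another group on this aromatic carbon, such as an amine or a carboxylic acid, would lower clearance while keeping the solubility of compound 4.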